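This account rests on a few compounds, and the source may have more. Where it says the series, first, only, none or still open, it means among the compounds named here.

In a functional assay on Caco-2 cells (Homo sapiens) for inhibition, read by MTT assay, with a stated time of 72 h (a higher number here means a weaker inhibitor, a lower number a stronger inhibitor), compound 1 `COc1cc(/C=C/C(=O)/C=C(/C=C/c2ccc(OC(C)=O)c(OC)c2)NC2CCCCC2)ccc1OC(C)=O` gives 9700 nM, and compound 2 `CC(C)CNC(=C\C(=O)/C=C/c1ccc(O)cc1)/C=C/c1ccc(O)cc1` gives the higher number of 23000 nM. Compound 3 `COc1cc(/C=C/C(=O)/C=C(/C=C/c2ccc(OC(C)=O)c(OC)c2)NCC(C)C)ccc1OC(C)=O` is reported as > 25000 nM, which is a limit of the assay and not a number.

Compound 4 `CCC(C)NC(=C\C(=O)/C=C/c1ccc(O)cc1)/C=C/c1ccc(O)cc1` departs from compound 2 in one place, with sec-butyl in place of isobutyl on an amine nitrogen. The two have the same atoms, joined differently.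

Among the compounds with values here, the only measured step at such a nitrogen is an at least 2.5-fold higher number from compound 1 to compound 3 (0.41 log units; beyond the scatter), where isobutyl takes the place of cyclohexyl. It bears on the present change only loosely, since it exchanges a ring for a chain on the core of compound 1, while the new change exchanges one butyl chain for another on the core of compound 2. Within the data shown here, no measured step covers a change between these two chains, so no step beyond the scatter is expected in this assay, in either direction. A small upward drift could still carry compound 4 to the limit of > 25000 nM in this assay, at which 1 of the 3 values shown sits.

The expected size of the change is a 1.2-fold lower number from compound 2 to compound 4 (0.06 log units; within the scatter). For compound 4 the estimated value is 20000 nM, with an expected range of 10000 nM to 35000 nM.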

Compound 4, half-maximal inhibitory concentration: 9400 nM
Compound 4: the middle estimate sits 2.1-fold (0.33 log units) above what was measured, and the stated range ends above it.
By their numbers in this assay, from the lowest: compounds 4 and 1 (each within the scatter of the next); then compound 2. At a limit, above all of these: compound 3.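

In this assay, sec-butyl in place of isobutyl on the amine nitrogen gives a 2.4-fold lower number from compound 2 to compound 4 (0.39 log units; beyond the scatter), so exchanging one butyl chain for another with the same count of heavy atoms is enough to move the number beyond the scatter. Within the data shown here, the only earlier step at such a nitrogen, an at least 2.5-fold higher number from compound 1 to compound 3 (0.41 log units; beyond the scatter), exchanged a ring for a chain on the core of compound 1, so it could not show whether the way a butyl chain is joined matters on its own. Compound 3 remains the only compound at a limit, which is not a number, and compound 4 does not join it: the limit of > 25000 nM in this assay, at which 1 of the 4 values shown sits.

The compounds shown leave open whether the same exchange would lower the number on the core of compound 1, and where a tert-butyl group or a cyclopentyl ring on this nitrogen would fall relative to sec-butyl. They also offer no measurement that says why the two butyl chains differ in this assay.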